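Carboxy for methoxy in a pyrrolidine amide series

The compounds below may be only part of what the source reports. "The series", "measured", "known", "first", "only" and "open" are said of these compounds alone.

The four compounds share one core. Compound 1 `COc1cccc(CCCCCCC(=O)N2CCCC2)c1` and compound 2 `COc1ccc(CCCCCCC(=O)N2CCCC2)cc1` each carry a methoxy group on the aromatic ring; how their two cores differ is not broken down here. Compound 3 `O=C(O)c1cccc(CCCCCCC(=O)N2CCCC2)c1` and compound 4 `O=C(O)c1ccc(CCCCCCC(=O)N2CCCC2)cc1` carry a carboxy group instead.

In an assay on HEK293 cells for inhibition of N-acylethanolamine-hydrolyzing acid amidase (Rattus norvegicus), read by LC-MS, with a stated time of 30 min (a higher number here means a weaker inhibitor, a lower number a stronger inhibitor), compound 1 gives only a limit, > 100000 nM. In this assay compound 2 gives 35400 nM. In this assay compound 3 likewise gives only a limit, > 100000 nM.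

The change from compound 1 to compound 3 is carboxy in place of methoxy on an aromatic carbon. Its size, a step that the two limits leave unreadable from compound 1 to compound 3, cannot be read because of the limit of > 100000 nM in this assay, at which 2 of the 3 values shown sit.

The change from compound 2 to compound 4 is carboxy in place of methoxy on an aromatic carbon. It is the same kind of change, but the place differs: in compound 3 the carboxy stands meta to a large group, in compound 4 para to a large group.

On these data alone, compound 2 is the only one of the three measured that yields a number, and its carboxy analogue is untested. Among the compounds with values here, the one measured carboxy compound, compound 3, sits at the limit, so compound 4 is expected to weaken as well, by an estimated 2.5-fold higher number from compound 2 to compound 4 (0.41 log units; beyond the scatter). For compound 4 in this assay the expected value is 90000 nM, between 25000 nM and 300000 nM, with a fair chance that only a limit is reported.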

Compound 4, half-maximal inhibitory concentration: > 100000 nM
Compound 4 gave a limit, no number; the forecaster's own chance of this, stated with the estimate: 55%; middle value at least 1.1-fold (0.04 log units) from the limit.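

Where the group stands para to a large group, carboxy in place of methoxy gives an at least 2.8-fold higher number from compound 2 to compound 4 (0.45 log units; beyond the scatter) in this assay. Compound 4 gives > 100000 nM, which is a limit of the assay and not a number, so the printed size of that step is a lower bound and the true step may be larger. The corresponding step on the other core cannot be read, so the data do not show that the change carries over from one core to the other with a similar size, only that both carboxy compounds end at the same limit, and no comparison of the two steps is possible because of the following: the limit of > 100000 nM in this assay, at which 3 of the 4 values shown sit.

Within the data shown here, with compound 2 as the only compound giving a number in this assay, the reading of this change rests on a single methoxy starting point, and how far any substituent on the aromatic ring matters on either core remains unresolved. On these data alone, whether an amine or a methyl ester in place of the carboxy, or a longer chain between the aromatic ring and the amide carbonyl, would bring these compounds into a measurable range stays open.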